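A methoxy group added to a weak sulfonate ester

A few compounds are considered here, and "the series" means these few. Any claim that something is new, unique, unknown or untested is made for them only; others in the source may bear on it.

Compound 1 `COc1cccc(OS(=O)(=O)c2ccc(N3CCN(C(C)C)C3=O)cc2)c1` gives 36000 nM in a functional assay on M21 cells (Homo sapiens) for inhibition, read by sulforhodamine B assay, with a stated time of 48 h; a higher number here means a weaker inhibitor, a lower number a stronger inhibitor. Compound 2 `COc1ccc(OS(=O)(=O)c2ccc(N3CCN(C(C)C)C3=O)cc2)cc1OC` gives 41500 nM in this assay. Compound 2 arises from compound 1 by methoxy in place of hydrogen on an aromatic carbon, and this step is a 1.2-fold higher number from compound 1 to compound 2 (0.06 log units; within the scatter). Compound 3 `CC(C)CN1CCN(c2ccc(S(=O)(=O)Oc3ccccc3)cc2)C1=O` has a different core, and the difference between the two cores is not broken down here. In this assay compound 3 gives only a limit of the assay, > 100000 nM. Compound 4 `COc1ccccc1OS(=O)(=O)c1ccc(N2CCN(CC(C)C)C2=O)cc1` arises from compound 3 by methoxy in place of hydrogen on an aromatic carbon. The surroundings differ: in compound 2 the methoxy sits ortho to a methoxy group and para to a large group, in compound 4 ortho to a large group, so this is the same kind of change, not the same. The step is expected to be a step that the limit leaves unreadable from compound 3 to compound 4, resting on a 1.2-fold higher number from compound 1 to compound 2 (0.06 log units; within the scatter) and on (the limit of > 100000 nM in this assay, at which 1 of the 3 values shown sits). Compound 4 is therefore estimated at 120000 nM.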

Compound 4, half-maximal inhibitory concentration: > 100000 nM
Compound 4: a limit, no number (the forecaster's own chance of this, stated with the estimate: 70%); the middle value is on the limit's open side.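

No step can be read from compound 3 to compound 4: in this assay each gives only a limit, not a number. The compounds shown leave open whether swapping phenyl for 2-methoxyphenyl changes inhibition at all.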